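A few compounds are considered here, and "the series" means these few. Any claim that something is new, unique, unknown or untested is made for them only; others in the source may bear on it.

In a functional assay on DU-145 cells (Homo sapiens) for inhibition, read by trypan blue exclusion, with a stated time of 96 h (on this read-out higher numbers stand for weaker inhibition of growth and lower numbers for stronger inhibition of growth), compound 1 `Cc1ccc(CS(=O)(=O)/C(=C/c2ccc(Br)cc2)C(=O)c2ccc(Cl)cc2)cc1` gives 25000 nM, level with compound 3 `Cc1ccc(CS(=O)(=O)/C(=C/c2ccc(Cl)cc2)C(=O)c2ccc(Cl)cc2)cc1` at 25000 nM. Compound 2 `Cc1ccc(CS(=O)(=O)/C(=C/c2c(O)cc(O)cc2O)C(=O)c2ccc(Cl)cc2)cc1` reads > 100000 nM, which is a limit of the assay and not a number.

Compound 4 `O=C(/C(=C\c1ccc(Br)cc1)S(=O)(=O)Cc1ccc(F)cc1)c1ccc(Cl)cc1` differs from compound 1 by fluoro in place of methyl on an aromatic carbon, with fluoro in place of methyl on an aromatic carbon, para to a large group. Two measured steps offer some guidance. The step of no change at the digits printed from compound 1 to compound 3 (within the scatter) swaps bromo for chloro and stays within the scatter. The step of an at least 4.0-fold higher number from compound 1 to compound 2 (0.60 log units; beyond the scatter) lies beyond the scatter, but it replaces 4-bromophenyl with 2,4,6-trihydroxyphenyl, a much larger change. Neither touches the 4-methylbenzyl group, so no measurement tests this change directly.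

The small swap in compound 3, with its step of no change at the digits printed from compound 1 to compound 3 (within the scatter), is the closer guide, so no step beyond the scatter is expected in this assay. The expected step is no change at the digits printed from compound 1 to compound 4 (within the scatter). The estimate for compound 4 is 25000 nM, with an expected range from 10000 nM to 60000 nM.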

Compound 4, concentration for 50% growth inhibition: > 100000 nM
Compound 4 ended at the assay's limit; the forecaster's own chance of this, stated with the estimate: 8%; middle value at least 4.0-fold (0.60 log units) away from the limit.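

In this assay the 4-methylbenzyl end of the molecule proves sensitive: fluoro in place of methyl on an aromatic carbon, para to a large group, gives an at least 4.0-fold higher number from compound 1 to compound 4 (0.60 log units; beyond the scatter). Going by these compounds alone, the earlier compounds changed only the 4-bromophenyl group, so this is the first sign that this position also matters, and one heavy atom exchanged for one other is enough to move the read-out beyond the scatter. Compound 4 reads > 100000 nM, which is a limit of the assay and not a number, and it shares that limit with compound 2: the limit of > 100000 nM in this assay, at which 2 of the 4 values shown sit.

The compounds shown leave open whether the loss follows from fluoro arriving or from methyl leaving, as only these two groups appear at this position. From the compounds shown here alone, how a hydrogen, a methoxy or an ethyl group would read there remains open, as does whether the same swap would have the same outcome on compound 3.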